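This account rests on a few compounds, and the source may have more. Where it says the series, first, only, none or still open, it means among the compounds named here.

Measured compounds:
Compound 1, `O=C(O)CCCCCCOc1cc(-c2ccccc2)c2ccccc2n1`, gives 1800 nM in an assay on membranes from spleen (Cavia porcellus) for binding affinity to leukotriene B4 receptor 1 (Homo sapiens); on this read-out lower numbers stand for stronger inhibition and higher numbers for weaker inhibition.
Compound 2, `CC(C)(CCCCOc1cc(-c2ccccc2)c2ccccc2n1)C(=O)O`, gives 183 nM.
Compound 3, `COc1cccc(-c2cc(OCCCCC(C)(C)C(=O)O)nc3ccccc23)c1`, gives 300 nM.

Compound 2 stands at the low end of the three numbers. Its nearest neighbour is compound 3, and the step of a 1.6-fold higher number from compound 2 to compound 3 (0.21 log units; within the scatter) lies within the scatter, so the two are not told apart on this read-out. For the measured compounds named here, the furthest is compound 1, separated by the step of a 9.8-fold lower number from compound 1 to compound 2 (0.99 log units; beyond the scatter), which concerns the acid-bearing chain and is the only step beyond the scatter among the measured compounds.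

Compound 4, `CC(C)(CCCCOc1cc(-c2cccc(Cl)c2)c2ccccc2n1)C(=O)O`, differs from compound 2 in one place: chloro in place of hydrogen on an aromatic carbon. The step that bears on this change is a 1.6-fold higher number from compound 2 to compound 3 (0.21 log units; within the scatter), where a methoxy entered an aromatic carbon of the same phenyl ring and left the number within the scatter. The step of a 9.8-fold lower number from compound 1 to compound 2 (0.99 log units; beyond the scatter) does not bear on it, since the chain and acid are unchanged. A chlorine at this place is therefore expected to give no step beyond the scatter, a 1.1-fold higher number from compound 2 to compound 4 (0.04 log units; within the scatter). The estimate for compound 4 is 200 nM, with a range from 80 nM to 500 nM.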

Compound 4, half-maximal inhibitory concentration: 1100 nM
For compound 4 the middle estimate is 5.5-fold (0.74 log units) below the measured one; the measured number lies above the stated range.
By their numbers in this assay, from the lowest: compounds 2 and 3 (each within the scatter of the next); then compounds 4 and 1 (each within the scatter of the next).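

In this assay this aromatic carbon proves not to be indifferent to substitution: chloro in place of hydrogen gives a 6.0-fold higher number from compound 2 to compound 4 (0.78 log units; beyond the scatter) and this is a step beyond the scatter, which the methoxy of compound 3 had not produced. The replacement of methoxy by chloro at the same carbon gives a 3.7-fold higher number from compound 3 to compound 4 (0.56 log units; beyond the scatter) so the outcome here depends on which group enters and not merely on the hydrogen being replaced. Nothing available accounts for this difference between the two groups.

The compounds shown leave open whether a fluoro, a methyl or an amine at this carbon would follow chloro or methoxy. They also leave open whether chloro on another carbon of the same ring would give a step of similar size.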